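From cyclopropyl to 2-hydroxyethyl on an amide-type nitrogen

The compounds below may be only part of what the source reports. "The series", "measured", "known", "first", "only" and "open" are said of these compounds alone.

Measured in a functional assay on HCT-116 cells (Homo sapiens) for antiproliferative activity, read by sulforhodamine B assay, with a stated time of 72 h; on this read-out lower numbers stand for stronger inhibition and higher numbers for weaker inhibition:
- compound 1 `Cn1ncc(Cl)c1-c1cc(C(=O)N[C@@H]2CN[C@H](CCCO)C[C@H]2c2ccc(Cl)c(Cl)c2)oc1Cl` gives 510 nM
- compound 2 `Cn1ncc(Cl)c1-c1cc(C(=O)N[C@@H]2CN[C@H](CC(N)=O)C[C@H]2c2ccc(Cl)c(Cl)c2)oc1Cl` gives 650 nM
- compound 3 `Cn1ncc(Cl)c1-c1cc(C(=O)N[C@@H]2CN[C@H](CC(=O)NC3CC3)C[C@H]2c2ccc(Cl)c(Cl)c2)oc1Cl` gives 740 nM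

In this assay, compound 3 lies within the scatter of both other measured compounds. The two steps that end there are a 1.5-fold higher number from compound 1 to compound 3 (0.16 log units; within the scatter) and a 1.1-fold higher number from compound 2 to compound 3 (0.06 log units; within the scatter).

Compound 4 `Cn1ncc(Cl)c1-c1cc(C(=O)N[C@@H]2CN[C@H](CC(=O)NCCO)C[C@H]2c2ccc(Cl)c(Cl)c2)oc1Cl` departs from compound 3 at a single place: 2-hydroxyethyl in place of cyclopropyl on an amide-type nitrogen. In words, 2-hydroxyethyl stands in place of cyclopropyl on an amide-type nitrogen.

The closest evidence is the step at that same nitrogen, where cyclopropyl took the place of hydrogen: a 1.1-fold higher number from compound 2 to compound 3 (0.06 log units; within the scatter). Two further changes, made one bond further out, also stayed small: a 1.3-fold higher number from compound 1 to compound 2 (0.11 log units; within the scatter) and a 1.5-fold higher number from compound 1 to compound 3 (0.16 log units; within the scatter). Within the data shown here, none of the three compounds goes against this picture, although they are few, and no measured compound carries 2-hydroxyethyl on this nitrogen.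

A step beyond the scatter is therefore not expected, and no direction can be favoured. The expected change is a 1.1-fold lower number from compound 3 to compound 4 (0.06 log units; within the scatter). The estimated value for compound 4 is 650 nM, with an expected range from 330 nM to 1300 nM.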

Compound 4, half-maximal inhibitory concentration: 670 nM
Compound 4: middle estimate off by 1.0-fold (0.01 log units), on the low side; low and high end bracket the measured number.
By their numbers in this assay, from the lowest: compounds 1, 2, 4 and 3 (each within the scatter of the next).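

In this assay, among these compounds, the result adds something the earlier compounds could not show: an open chain bearing oxygen, with one hydrogen-bond donor and one hydrogen-bond acceptor, can replace a three-membered carbon ring on this amide-type nitrogen with only a small step, namely a 1.1-fold lower number from compound 3 to compound 4 (0.04 log units; within the scatter). Hydrogen, cyclopropyl and 2-hydroxyethyl can now all be compared at this nitrogen, and the newly available comparison with hydrogen also remains small, at a 1.0-fold higher number from compound 2 to compound 4 (0.01 log units; within the scatter). The longer replacement of 2-hydroxyethyl by (2-hydroxyethyl)carbamoyl on the saturated chain carbon bound to a saturated ring carbon gives a 1.3-fold higher number from compound 1 to compound 4 (0.12 log units; within the scatter), so all of the changes seen in this side chain so far remain within the scatter, and none of the four compounds goes against that.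

No measurement here offers an explanation for why these steps stay so small. The compounds shown leave open whether an amine, a carboxylic acid or a longer chain on this amide-type nitrogen would also stay within the scatter, and whether any change away from this side chain, on the shared core, would produce a larger step.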